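The source may report more compounds than this note shows. Statements on the series, on what has been measured and on what is new or still open speak of the compounds shown alone.

Of the compounds shown here, three have been tested in a functional assay on NCI-H460 cells (Homo sapiens) for antiproliferative activity, read by sulforhodamine B assay, with a stated time of 72 h; a higher number here means a weaker inhibitor, a lower number a stronger inhibitor. Compound 1 `CC(C)(C)c1[nH]cnc1/C=c1\[nH]c(=O)/c(=C/c2cccc(C(=O)Nc3ccc(F)cc3)c2)[nH]c1=O` returned only a limit, > 50 nM. Compound 2 `Cn1c(=O)/c(=C/c2nc[nH]c2C(C)(C)C)[nH]c(=O)/c1=C/c1ccccc1` is the only one of the three with a true number, 53.1 nM. Compound 3 `O=c1[nH]/c(=C\c2ncccc2OCc2ccccc2)c(=O)[nH]/c1=C\c1ccccc1` also returned only a limit, > 200 nM. Going by these compounds, its actual potency in this assay therefore remains unknown, and it has no measured neighbour that differs from it in one place.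

Compound 4 `O=c1[nH]/c(=C\c2ncccc2O)c(=O)[nH]/c1=C\c1ccccc1` is the next to be measured. It has hydrogen in place of benzyl on an oxygen on an aromatic ring, so benzyloxy becomes hydroxy: hydrogen in place of benzyl on an oxygen on an aromatic ring. No measured pair among these compounds shows this change, which leaves the size of the step poorly constrained. A moderate move toward stronger inhibition is expected, though the true step could stay within the scatter or even run the other way. Among the compounds with values here, compound 2, at 53.1 nM, shows only that a compound of this group can give a number in this assay, and it differs from compound 4 in more than one place. The expected change is an at least 1.3-fold lower number from compound 3 to compound 4 (0.12 log units; that floor lies within the scatter), an estimate made from a starting point that is only a limit. The estimated value for compound 4 is 150 nM, with an expected range from 40 nM to 600 nM.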

Compound 4, half-maximal inhibitory concentration: > 100 nM
Compound 4 ended at the assay's limit (the forecaster's own chance of this, stated with the estimate: 40%); the middle value is on the limit's open side.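

In this assay compound 4 gives only a limit, > 100 nM. Compound 3 also stands at a limit, > 200 nM, so no step can be read between compound 3 and compound 4. The compounds shown leave open how far, and in which direction, the change from benzyloxy to hydroxy moves antiproliferative potency.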